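This account rests on a few compounds, and the source may have more. Where it says the series, first, only, none or still open, it means among the compounds named here.

In a functional assay on cells for agonist activity at G-protein coupled receptor 52 (Homo sapiens), read by AlphaScreen and cAMP accumulation, with a stated time of 30 min (a lower number here means that less compound is needed, a higher number that more compound is needed for the effect), compound 1 `Cc1cc(-c2sc(Cc3cccc(C(F)(F)F)c3)nc2C)ccc1C(N)=O` gives 73 nM. Compound 2 `Cc1nc(Cc2cccc(C(F)(F)F)c2)sc1-c1ccc(C(N)=O)c(C(C)C)c1` gives 370 nM, and compound 3 `Cc1nc(Cc2cccc(C(F)(F)F)c2)sc1-c1ccc(C(N)=O)c(F)c1` gives 380 nM. That number is the highest of the three, though a 1.0-fold higher number from compound 2 to compound 3 (0.01 log units; within the scatter) lies within the scatter, while a 5.2-fold higher number from compound 1 to compound 3 (0.72 log units; beyond the scatter) lies beyond it. Compound 4 `Cc1nc(Cc2cccc(C(F)(F)F)c2)sc1-c1ccc(C(N)=O)c(C(F)(F)F)c1` differs from compound 3 in one place: trifluoromethyl in place of fluoro on an aromatic carbon. For the measured compounds named here, the steps that bear on this are a 5.1-fold higher number from compound 1 to compound 2 (0.70 log units; beyond the scatter) and a 5.2-fold higher number from compound 1 to compound 3 (0.72 log units; beyond the scatter), which show that a small group and a much larger one on that aromatic carbon give about the same number, so the step of a 1.1-fold higher number from compound 3 to compound 4 (0.02 log units; within the scatter) is expected to stay within the scatter in this assay. Compound 4 is therefore expected to give 400 nM, between 150 nM and 1200 nM.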

Compound 4, half-maximal effective concentration: 110 nM
For compound 4 the middle estimate is 3.6-fold (0.56 log units) above the measured one, and the stated range ends above it.
By their numbers in this assay, from the lowest: compounds 1 and 4 (each within the scatter of the next); then compounds 2 and 3 (each within the scatter of the next).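

For the compounds shown here, at this position, ortho to a carbamoyl group, the earlier compounds suggested that swapping the group changes little, but a 3.5-fold lower number from compound 3 to compound 4 (0.54 log units; beyond the scatter) and a 3.4-fold lower number from compound 2 to compound 4 (0.53 log units; beyond the scatter), both beyond the scatter in this assay, show that the choice of group does matter. With a 1.5-fold higher number from compound 1 to compound 4 (0.18 log units; within the scatter), trifluoromethyl matches methyl here, so the number does not simply follow group size. Nothing shown gives a reason for this.

Going by these compounds, whether an amine, a methoxy group or a carboxylic acid at this position would side with compound 1 and compound 4 or with compound 2 and compound 3 stays open.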